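The compounds below may be only part of what the source reports. "The series", "measured", "known", "first", "only" and "open" are said of these compounds alone.

Values in a functional assay on HCT-116 cells (Homo sapiens) for antiproliferative activity, read by CellTiter-Glo, with a stated time of 72 h; a higher number here means a weaker inhibitor, a lower number a stronger inhibitor
- compound 1 `O=C(NO)c1ccc(/C=C/c2ccnc(-c3cc(F)ccc3O)c2)cc1` gives 2040 nM
- compound 2 `O=C(NO)c1ccc(/C=C/c2ccnc(-c3ccccc3O)c2)cc1` gives 1450 nM
- compound 3 `O=C(NO)c1ccc(/C=C/c2ccnc(-c3cccc(CO)c3)c2)cc1` gives 1700 nM
- compound 4 `O=C(NO)c1ccc(/C=C/c2ccnc(-c3ccc(F)cc3)c2)cc1` is not yet measured

Compound 3, at 1700 nM, lies within the scatter of the other two values. The steps that reach it are a 1.2-fold higher number from compound 2 to compound 3 (0.07 log units; within the scatter) and a 1.2-fold lower number from compound 1 to compound 3 (0.08 log units; within the scatter).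

The next step is 4-fluorophenyl in place of 3-(hydroxymethyl)phenyl on an aromatic carbon. It places 4-fluorophenyl in place of 3-(hydroxymethyl)phenyl on an aromatic carbon, next to the ring nitrogen.

Both steps above changed the group at this same place, and neither moved the number beyond the scatter. Fluoro on the ring was also exchanged once, in a 1.4-fold lower number from compound 1 to compound 2 (0.15 log units; within the scatter), again without a step beyond the scatter. These steps are small, so no step beyond the scatter is expected here.

The caution is that all three measured groups carry a hydroxy group and 4-fluorophenyl does not. Among the compounds with values here, no measured step tests that loss, so the range is kept wider than the spread of the three values.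

The expected step is a 1.1-fold lower number from compound 3 to compound 4 (0.03 log units; within the scatter).

The estimate for compound 4 is 1600 nM, with an expected range of 700 nM to 3500 nM.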

Compound 4, half-maximal inhibitory concentration: > 10000 nM
Compound 4 was reported as a limit; the forecaster's own chance of this, stated with the estimate: 3%; at least 6.2-fold (0.79 log units) between middle value and limit.
By their numbers in this assay, from the lowest: compounds 2, 3 and 1 (each within the scatter of the next). At a limit, above all of these: compound 4.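

In this assay compound 4 stands as a limit and not as a number: the limit of > 10000 nM in this assay, at which 1 of the 4 values shown sits. The place next to the ring nitrogen is therefore not indifferent to the group it carries, since the three hydroxy-bearing groups gave values within the scatter of each other, whereas an at least 5.8-fold higher number from compound 3 to compound 4 (0.76 log units; beyond the scatter), an at least 6.8-fold higher number from compound 2 to compound 4 (0.83 log units; beyond the scatter) and an at least 4.9-fold higher number from compound 1 to compound 4 (0.69 log units; beyond the scatter) all lie beyond it. Across these compounds, the drop goes with 4-fluorophenyl, the only group here without a hydroxy group, and fluoro by itself does not track it, as compound 1 carries fluoro in 5-fluoro-2-hydroxyphenyl and stays with compounds 2 and 3.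

Still open, from the compounds shown here alone, is whether the hydroxy group itself is what counts or whether the fluoro at this ring location works against activity, a question that plain phenyl would help to separate. A methoxy group or an amine in place of the hydroxy group would show whether other groups can stand in for it, and how far the hydroxy group can move on the ring also remains unsettled.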